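Cytotoxicity on HeLa cells: compound 3 and its demethyl analogue

The source may report more compounds than this note shows. Statements on the series, on what has been measured and on what is new or still open speak of the compounds shown alone.

Measured compounds in a functional assay on HeLa cells (Homo sapiens) for cytotoxicity, read by MTT assay; a lower number here means a stronger inhibitor, a higher number a weaker inhibitor:
- compound 1 `CC(=O)c1ccc2c(c1O)[C@@H]1c3c(ccc4c(=O)c(C)c(C)oc34)OC[C@@H]1C(C)(C)O2`: in this assay compound 1 gives > 100000 nM, a limit of the assay.
- compound 2 `CC(=O)c1ccc2c(c1O)[C@H]1c3c(ccc4c(=O)c(C)coc34)OC[C@H]1C(C)(C)O2`: in this assay compound 2 gives > 100000 nM, a limit of the assay.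
- compound 3 `Cc1oc2c3c(ccc2c(=O)c1C)OC[C@H]1[C@@H]3c2ccc3ccccc3c2OC1(C)C`: in this assay compound 3 gives > 100000 nM, a limit of the assay.

Compound 3 stands nowhere distinct among the numbers shown: all three values sit at the same limit, (the limit of > 100000 nM in this assay, at which 3 of the 3 values shown sit), so no ordering among compound 1, compound 2 and compound 3 can be drawn.

Compound 4 `Cc1coc2c3c(ccc2c1=O)OC[C@H]1[C@@H]3c2ccc3ccccc3c2OC1(C)C` differs from compound 3 by hydrogen in place of methyl on an aromatic carbon, in words hydrogen in place of methyl on an aromatic carbon. Within the data shown here, no step between measured compounds exists to calibrate this change. Given that compound 3 gives > 100000 nM and that the whole series sits at the limit, the expectation for compound 4 is a step that the limit leaves unreadable from compound 3 to compound 4, that is, none beyond the scatter. Compound 4 is expected at 150000 nM, between 50000 nM and 500000 nM, most likely again reported as a limit.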

Compound 4, half-maximal inhibitory concentration: > 100000 nM
Compound 4: no number, only a limit; the forecaster's own chance of this, stated with the estimate: 90%; the middle value is on the limit's open side.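

In this assay compound 4 returns only a limit, as compound 3 does, so no step can be read from compound 3 to compound 4: the limit of > 100000 nM in this assay, at which 4 of the 4 values shown sit.

The compounds shown leave open what hydrogen in place of methyl on an aromatic carbon changes, and whether any close analogue gives a readable value in this assay.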